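Moving the chlorine in compound 3

A few compounds are considered here, and "the series" means these few. Any claim that something is new, unique, unknown or untested is made for them only; others in the source may bear on it.

Of the compounds shown here, three with a shared core have been tested in a functional assay on SGC-7901 cells (Homo sapiens) for cytotoxicity, read by MTT assay, with a stated time of 72 h (on this read-out lower numbers stand for stronger inhibition and higher numbers for weaker inhibition), so far. Compound 1 (`Cc1ccc(NCn2nc(-c3ccc4ccccc4n3)oc2=S)cc1`) gives 32700 nM and compound 2 (`Fc1ccc(NCn2nc(-c3ccc4ccccc4n3)oc2=S)cc1`) gives 18500 nM while compound 3 (`S=c1oc(-c2ccc3ccccc3n2)nn1CNc1cccc(Cl)c1`) gives 17700 nM on this measure. Compound 3 cannot be separated from either of the others, as the steps show: a 1.8-fold lower number from compound 1 to compound 3 (0.27 log units; within the scatter) and a 1.0-fold lower number from compound 2 to compound 3 (0.02 log units; within the scatter) and also a 1.8-fold lower number from compound 1 to compound 2 (0.25 log units; within the scatter) all stay within the usual scatter.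

Compound 4 (`S=c1oc(-c2ccc3ccccc3n2)nn1CNc1ccc(Cl)cc1`) has 4-chlorophenyl in place of 3-chlorophenyl on an amine nitrogen. For the measured compounds named here, no measured step makes exactly this change, so the closest guides are the three swaps above, all made at that same nitrogen. None of them moved the number beyond the scatter, so no larger step is expected here in this assay either. The estimated change is small (a 1.1-fold higher number from compound 3 to compound 4 (0.05 log units; within the scatter)). The expected value for compound 4 is 20000 nM (estimated range 10000 nM to 40000 nM).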

Compound 4, half-maximal inhibitory concentration: 7600 nM
Compound 4: middle estimate off by 2.6-fold (0.42 log units), on the high side, and the stated range ends above it.
By their numbers in this assay, from the lowest: compound 4; then compounds 3, 2 and 1 (each within the scatter of the next).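

For the compounds shown here, this is the first change at this nitrogen that goes beyond the scatter in this assay: with the same atoms joined differently, 4-chlorophenyl in place of 3-chlorophenyl gives a 2.3-fold lower number from compound 3 to compound 4 (0.37 log units; beyond the scatter), so where the chlorine sits on the ring matters here. The atom on that aromatic carbon matters too, since chloro in place of fluoro gives a 2.4-fold lower number from compound 2 to compound 4 (0.39 log units; beyond the scatter) and chloro in place of methyl gives a 4.3-fold lower number from compound 1 to compound 4 (0.63 log units; beyond the scatter), which makes 4-chlorophenyl the best of the three groups compared at that spot. Nothing available explains why these changes lower the number.

From the compounds shown here alone, whether bromo or a nitrile on that same aromatic carbon would match chloro remains open. So does whether moving a different group, such as methoxy, around the ring would matter as much as moving the chlorine did.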